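A few compounds are considered here, and "the series" means these few. Any claim that something is new, unique, unknown or untested is made for them only; others in the source may bear on it.

Of the compounds shown here, three built on one shared core have been measured so far. In a functional assay on MKN-45 cells (Homo sapiens) for cytotoxicity (on this read-out lower numbers stand for stronger inhibition and higher numbers for weaker inhibition), compound 1 `COc1ccc(S(=O)(=O)N2CCc3cccc(NC(=O)c4ccc([N+](=O)[O-])cc4)c32)cc1` gives 95 nM, compound 2 `COc1ccc(S(=O)(=O)N2CCc3cc(Br)cc(NC(=O)c4ccco4)c32)cc1` gives 78 nM, and compound 3 `COc1ccc(S(=O)(=O)N2CCc3cccc(NC(=O)c4ccncc4)c32)cc1` gives 8.8 nM. Compound 3 therefore shows the lowest number of the three, and its gap to compound 2 as well as to compound 1 lies beyond the usual scatter, so it is the strongest inhibitor among them.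

Compound 4 `COc1ccc(S(=O)(=O)N2CCc3cccc(NS(=O)(=O)c4ccc(F)cc4)c32)cc1` has not yet been measured. It differs from compound 3 in a single place: (4-fluorophenyl)sulfonyl in place of (pyridin-4-yl)carbonyl on a nitrogen on an aromatic ring. Among the compounds with values here, only one measured step speaks to this change, namely an 11-fold lower number from compound 1 to compound 3 (1.03 log units; beyond the scatter). Read in reverse, that step says that giving up pyridin-4-yl for a six-membered aromatic ring of carbon only raised the number by a large amount. Within the data shown here, compound 4 makes the same kind of exchange of ring, but at the same time the carbonyl is replaced by a sulfonyl, and no measured pair shows what that part of the change does. A step upward is therefore expected, a 9.1-fold higher number from compound 3 to compound 4 (0.96 log units; beyond the scatter), though with wide uncertainty around it. Compound 4 is estimated at 80 nM, within a range from 20 nM to 400 nM.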

Compound 4, half-maximal inhibitory concentration: 890 nM
Compound 4: the middle estimate sits 11-fold (1.05 log units) below what was measured, and the stated range ends below it.
By their numbers in this assay, from the lowest: compound 3; then compounds 2 and 1 (each within the scatter of the next); then compound 4.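

In this assay, replacing (pyridin-4-yl)carbonyl with (4-fluorophenyl)sulfonyl on the nitrogen on the aromatic ring gives a 100-fold higher number from compound 3 to compound 4 (2.00 log units; beyond the scatter) and so makes inhibition much weaker. Within the data shown here, the only earlier step at this place, an 11-fold lower number from compound 1 to compound 3 (1.03 log units; beyond the scatter), exchanged one ring for another while the carbonyl stayed, so it showed only what a change of ring can do. The new step shows that a change at this place which removes the carbonyl as well can raise the number further, and that a six-membered aromatic ring of carbon only joined through a sulfonyl gives up the low number seen for compound 3.

The ring and the sulfonyl changed together here, so their shares in the rise cannot be separated, and pyridin-4-yl on a sulfonyl or 4-fluorophenyl on a carbonyl would each be needed to tell them apart. Nothing available here gives a measured reason for the rise in the number.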